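Alkoxy Extension in a Bromomethyl Chromone Series

The compounds below may be only part of what the source reports. "The series", "measured", "known", "first", "only" and "open" are said of these compounds alone.

Compound 1 `CCc1cc(=O)c2ccc(OC)c(CBr)c2o1` carries a methoxy group, an ethyl chain and a bromomethyl group on the shared core. In a functional assay on DU-145 cells (Homo sapiens) for antiproliferative activity, read by sulforhodamine B assay, with a stated time of 72 h (on this read-out higher numbers stand for weaker inhibition of growth and lower numbers for stronger inhibition of growth), compound 1 gives > 33600 nM, a limit of the assay and not a number. Compound 2 `CCOc1ccc2c(=O)cc(CC)oc2c1CBr` differs from compound 1 by methyl in place of hydrogen on a saturated chain carbon bound to an oxygen on an aromatic ring. In this assay compound 2 gives > 32100 nM, again only a limit. Compound 1 sits at the limit of > 33600 nM in this assay, at which 1 of the 3 values shown sits. Compound 2 sits at the limit of > 32100 nM in this assay, at which 1 of the 3 values shown sits. The step therefore reads a step that the two limits leave unreadable from compound 1 to compound 2. Within the data shown here, compound 3 `CCOc1ccc2c(=O)cc(C(C)Br)oc2c1CBr` carries a further bromine; in this assay compound 3 gives 20900 nM, the only number in the set, and the step is an at least 1.5-fold lower number from compound 2 to compound 3 (0.18 log units; that floor lies within the scatter). The difference between the core of compound 1 and that of compound 3 is not broken down here. Compound 4 `CC(C)Oc1ccc2c(=O)cc(C(C)Br)oc2c1CBr` is the unmeasured member and differs from compound 3 by methyl in place of hydrogen on a saturated chain carbon bound to an oxygen on an aromatic ring and a saturated chain carbon. This is the same kind of change as that from compound 1 to compound 2, not the same one: here the saturated chain carbon is bound to an oxygen on an aromatic ring and a saturated chain carbon, whereas in the earlier change it is bound to an oxygen on an aromatic ring only. Set against that earlier, unreadable step, for compound 4 the expected step is a 1.1-fold higher number from compound 3 to compound 4 (0.02 log units; within the scatter), resting on compound 3 at 20900 nM and on no readable precedent for the change. Compound 4 is estimated at 22000 nM in this assay, within 9000 nM to 55000 nM.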

Compound 4, concentration for 50% growth inhibition: 15500 nM
Compound 4: the middle estimate sits 1.4-fold (0.15 log units) above what was measured; the measured number falls inside the stated range.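

In this assay, among these compounds, the change from ethoxy to isopropoxy gives a 1.3-fold lower number from compound 3 to compound 4 (0.13 log units; within the scatter) and so shows only that this pair cannot be told apart. The step of the same kind on the core of compound 1, from methoxy to ethoxy, cannot be read, so nothing here shows whether the change carries from one core to another or what size it would have there. Compound 2, at one end of that step, is a limit of the assay and not a number: the limit of > 32100 nM in this assay, at which 1 of the 4 values shown sits.

The compounds shown leave open whether an isopropoxy group on the core of compound 1 would give a readable number in this assay and whether the ethoxy to isopropoxy result on the core of compound 3 would hold for a longer chain such as butoxy. They also leave open what an amine or a carboxylic acid at the end of that chain would do.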